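Aryloxypropyl piperidines on rabbit aorta: notes toward compound 4

The compounds below may be only part of what the source reports. "The series", "measured", "known", "first", "only" and "open" are said of these compounds alone.

The series shares a piperidine carrying a diarylmethyl group and a three-carbon chain ending in an aryl ether; only the aryl ether and the diaryl part vary. Compound 1 `COc1cc(C(C)=O)ccc1OCCCN1CCC(C(c2ccc(F)cc2F)c2ccc(F)cc2F)CC1` gives 15.9 nM in a functional assay (aorta) with Oryctolagus cuniculus as the target; on this read-out higher numbers stand for weaker binding and lower numbers for tighter binding. Compound 2 `COc1cc(C(C)=O)ccc1OCCCN1CCC(C(c2ccc(F)cc2)c2ccccn2)CC1` gives 158 nM in this assay. Compound 3 `COc1cc(C(=O)O)ccc1OCCCN1CCC(C(c2ccc(F)cc2)c2ccc(F)cc2)CC1` gives 79.4 nM in this assay. Among the three numbers compound 3 stands second highest; its gap to compound 2 is within the scatter, so no order between those two is claimed, while compound 1 lies beyond the scatter below it. Compound 1 and compound 3 differ in more than one place, so their two values say only that the series spans a clear range without pinning the change to any single group.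

Compound 4 `Fc1ccc(C(c2ccc(F)cc2)C2CCN(CCCOc3cccc4ccccc34)CC2)cc1` is not yet measured. It differs from compound 3 as follows: naphthalen-1-yl in place of 4-carboxy-2-methoxyphenyl on an oxygen on a saturated carbon. Within the data shown here, no measured pair isolates this change, so direction rests on the spread already seen. The step of a 2.3-fold lower number from compound 3 to compound 4 (0.36 log units; beyond the scatter) is expected to be modest and, if anything, toward tighter binding, since the values of compound 1 and compound 3 show the aryl ether end accepts variation. Compound 4 is estimated at 35 nM, with a range from 6 nM to 200 nM.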

Compound 4, dissociation constant: 5.01 nM
The estimate for compound 4 lay 7.0-fold (0.84 log units) above the measured number; measured number outside the range, below it.
By their numbers in this assay, from the lowest: compound 4; then compound 1; then compounds 3 and 2 (each within the scatter of the next).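

Working notes after compound 4

Read in this assay and with the rest of the molecule held constant, naphthalen-1-yl in place of 4-carboxy-2-methoxyphenyl gives a 16-fold lower number from compound 3 to compound 4 (1.20 log units; beyond the scatter) and is the first change in the series confined to one place. The group on the ether oxygen is therefore more than a site that accepts variation: a change here alone moves the number strongly, and the tighter binding of compound 4 requires neither the carboxy nor the methoxy group, nor any hydrogen-bond donor or acceptor on this aryl group. No measurement shown gives a reason for the step.

This single step removes the carboxylic acid and the methoxy group and brings in the fused second aromatic ring all at once, so their separate contributions stay unresolved. As far as these compounds go, a plain phenyl ether, a methyl ester in place of the carboxylic acid and a naphthalen-2-yl ether would each help to separate them, and it also remains open whether naphthalen-1-yl gives a similar step with the diaryl parts of compound 1 or compound 2.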